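The source may report more compounds than this note shows. Statements on the series, on what has been measured and on what is new or still open speak of the compounds shown alone.

Working notes on the series. Compound 1 `Cc1ccc(S(=O)(=O)Nc2ccc3c(c2)C(=O)N(CCNc2ccccc2)C3=O)cc1` carries the (4-methylphenyl)sulfonyl and the anilinomethyl chain; in an assay on isolated protein for inhibition of lactase/phlorizin hydrolase (Rattus norvegicus), read by colorimetric assay (on this read-out lower numbers stand for stronger inhibition and higher numbers for weaker inhibition), compound 1 gives 177000 nM. Compound 2 `Cc1ccc(S(=O)(=O)Nc2ccc3c(c2)C(=O)N(Cc2ccc(Cl)c(Cl)c2)C3=O)cc1` keeps the sulfonyl and swaps the chain; in this assay compound 2 gives 101000 nM, so a 1.8-fold lower number from compound 1 to compound 2 (0.24 log units; within the scatter). Compound 3 `Nc1ccc2c(c1)C(=O)N(CCNc1ccccc1)C2=O` keeps the chain and loses the sulfonyl. In this assay compound 3 reaches only a limit of the assay, > 200000 nM. The step is an at least 1.1-fold higher number from compound 1 to compound 3 (0.05 log units; that floor lies within the scatter); the floor rests on (the limit of > 200000 nM in this assay, at which 1 of the 3 values shown sits). Compound 3 therefore stands at the limit, with no numerical value of its own, and the measured steps to it and between compounds 1 and 2 both lie within the scatter.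

Compound 4 `O=C1c2ccccc2C(=O)N1CCNc1ccccc1` is the next case: hydrogen in place of amino on an aromatic carbon. Going by the values given here, no measured step touches this position; the two steps on record, a 1.8-fold lower number from compound 1 to compound 2 (0.24 log units; within the scatter) and an at least 1.1-fold higher number from compound 1 to compound 3 (0.05 log units; that floor lies within the scatter), alter other places and are both within the scatter. A change beyond the scatter is not expected here either; the expected step is a step that the limit leaves unreadable from compound 3 to compound 4. Compound 4 is therefore expected to give 300000 nM in this assay, estimated between 100000 nM and 1000000 nM, most likely again reported only as a limit.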

Compound 4, half-maximal inhibitory concentration: > 200000 nM
Compound 4 ended at the assay's limit; the forecaster's own chance of this, stated with the estimate: 70%; the middle value lies beyond the limit too.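

Compound 3 and compound 4 both stand at a limit of this assay, so no step can be read from compound 3 to compound 4: the limit of > 200000 nM in this assay, at which 2 of the 4 values shown sit.

The compounds shown leave open whether hydrogen in place of amino on this aromatic carbon changes inhibition at all, since neither compound has a numerical value of its own.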